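The source may report more compounds than this note shows. Statements on the series, on what has been measured and on what is new or still open speak of the compounds shown alone.

Compound 1 `Cc1ccc(C(=O)c2cc(Cl)ccc2Oc2ccnc(Nc3ccc(C#N)cc3)n2)cc1`: 1710 nM
Compound 2 `Cc1ccc(C(=O)c2cc(Cl)ccc2Oc2cc(C)nc(Nc3ccc(C#N)cc3)n2)cc1`: 26600 nM

Among the compounds with values here, in an ADME assay on MT4 cells (Homo sapiens) for cytotoxicity, read by MTT assay, with a stated time of 5 days (a higher number here means that more compound is tolerated, a lower number that less compound is tolerated), compound 2 gives 26600 nM, the highest of the two numbers measured so far; its nearest neighbour is compound 1, which gives 1710 nM. Within the data shown here, the only measured step, a 16-fold higher number from compound 1 to compound 2 (1.19 log units; beyond the scatter), concerns a methyl placed on the shared core and says nothing about the ring that sits on the carbonyl. Compound 3 `Cc1cc(Oc2ccc(Cl)cc2C(=O)c2ccccc2C)nc(Nc2ccc(C#N)cc2)n1` differs from compound 2 by 2-methylphenyl in place of 4-methylphenyl on a carbonyl carbon; the two compounds have the same atoms, joined differently, and everything else stays the same. Among the measured compounds shown here, no measured pair shows what such a rearrangement does in this assay, so there is no basis for expecting a shift beyond the scatter in either direction. Compound 3 is therefore estimated at 26600 nM, within 8000 nM to 80000 nM, which means an expected step of no change at the digits printed from compound 2 to compound 3 (within the scatter), inside the usual scatter.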

Compound 3, half-maximal cytotoxic concentration: 4240 nM
Compound 3: the middle estimate sits 6.3-fold (0.80 log units) above what was measured, and the stated range ends above it.
By their numbers in this assay, from the lowest: compound 1; then compound 3; then compound 2.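

Shifting the methyl within the ring on the carbonyl carbon, from 4-methylphenyl to 2-methylphenyl, gives a 6.3-fold lower number from compound 2 to compound 3 (0.80 log units; beyond the scatter) in this assay. The two compounds have the same atoms, joined differently, so this ring is a second place where the number responds, and where the methyl sits on it counts, which the earlier step on the shared core could not show. Nothing measured here explains why the position of the methyl matters.

As far as these compounds go, it remains open whether the change to 2-methylphenyl would give a similar step on the core of compound 1, which lacks the core methyl. From the compounds shown here alone, it is also open what another group on this ring, such as a methoxy group or an amine in place of the methyl, would do to the number.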